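Bis(trifluoromethyl)sulfonamide series: benzodioxinyl to bromophenyl

A few compounds are considered here, and "the series" means these few. Any claim that something is new, unique, unknown or untested is made for them only; others in the source may bear on it.

Compound 1 `O=S(=O)(NCCCNCc1ccc(Cl)c(Cl)c1)c1cc(C(F)(F)F)cc(C(F)(F)F)c1` gives 2400 nM in a functional assay on MCF7 cells (Homo sapiens) for inhibition, read by MTT assay, with a stated time of 72 h; a lower number here means a stronger inhibitor of growth, a higher number a weaker inhibitor of growth. Among the measured compounds shown here, compound 2 `O=S(=O)(NCCCNCC1COc2ccccc2O1)c1cc(C(F)(F)F)cc(C(F)(F)F)c1` gives 2500 nM, the higher of the two numbers so far, with compound 1 nearest: a 1.0-fold higher number from compound 1 to compound 2 (0.02 log units; within the scatter). Compound 3 `O=S(=O)(NCCCNCc1ccc(Br)cc1)c1cc(C(F)(F)F)cc(C(F)(F)F)c1` carries 4-bromophenyl in place of 2,3-dihydro-1,4-benzodioxin-2-yl on a saturated chain carbon bound to an amine nitrogen. For the measured compounds named here, the only measured step at this position, a 1.0-fold higher number from compound 1 to compound 2 (0.02 log units; within the scatter), swapped one group for another without leaving the scatter, so for compound 3 no step beyond the scatter in this assay is expected in either direction. Compound 3 is estimated at 2600 nM, range 1200 nM to 6000 nM, which means an expected step of a 1.0-fold higher number from compound 2 to compound 3 (0.02 log units; within the scatter).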

Compound 3, concentration for 50% growth inhibition: 1900 nM
For compound 3 the middle estimate is 1.4-fold (0.14 log units) above the measured one, and the stated range covers the measured number.
By their numbers in this assay, from the lowest: compounds 3, 1 and 2 (each within the scatter of the next).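

With 4-bromophenyl, a third group on a saturated chain carbon bound to an amine nitrogen stays within the scatter in this assay, with a 1.3-fold lower number from compound 2 to compound 3 (0.12 log units; within the scatter) and a 1.3-fold lower number from compound 1 to compound 3 (0.10 log units; within the scatter). Across these changes, the group entering has no hydrogen-bond acceptors where 2,3-dihydro-1,4-benzodioxin-2-yl has 2, yet no step leaves the scatter. No supporting data explain this flat result. Still open, going by these compounds, is whether a carboxylic acid, a primary amine or a longer chain at this position would produce a step beyond the scatter.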